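Cyclohexyloxy to benzyloxy in the pyridylthiourea series

The source may hold more compounds than are shown below. What is called first, only, known or untested is meant among the compounds shown, and "the series" means these compounds.

Compound 3 `S=C(Nc1cccnc1)NC1CCN(c2cc(OC3CCCCC3)ccn2)CC1` carries cyclohexyloxy on an aromatic ring. In an assay on membranes from brain for binding affinity to Lysophosphatidylserine lipase ABHD12 (Mus musculus), read by fluorescence, with a stated time of 20 min (on this read-out higher numbers stand for weaker inhibition and lower numbers for stronger inhibition), compound 3 gives 3400 nM, the highest of the three numbers; compound 2 `Cc1cnc(N2CCC(NC(=S)Nc3cccnc3)CC2)c(Cl)c1` gives 3100 nM, within the scatter of it, while compound 1 `FC(F)(F)c1cnc(N2CCC(NC(=S)Nc3cccnc3)CC2)c(Cl)c1` gives 1100 nM, beyond the scatter. Among the compounds with values here, the only measured step, a 2.8-fold higher number from compound 1 to compound 2 (0.45 log units; beyond the scatter), concerns methyl in place of trifluoromethyl on an aromatic carbon and does not touch the oxygen on the aromatic ring. Compound 4 `S=C(Nc1cccnc1)NC1CCN(c2cc(OCc3ccccc3)ccn2)CC1` differs from compound 3 by benzyl in place of cyclohexyl on an oxygen on an aromatic ring. Nothing measured bears on this change, so no step beyond the scatter is expected in this assay. For compound 4 the expected step is a 1.1-fold lower number from compound 3 to compound 4 (0.05 log units; within the scatter). Compound 4 is therefore estimated at 3000 nM, between 1000 nM and 9000 nM.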

Compound 4, half-maximal inhibitory concentration: 2800 nM
The estimate for compound 4 lay 1.1-fold (0.03 log units) above the measured number; low and high end bracket the measured number.
By their numbers in this assay, from the lowest: compound 1; then compounds 4, 2 and 3 (each within the scatter of the next).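

On the oxygen on the aromatic ring, benzyl in place of cyclohexyl gives a 1.2-fold lower number from compound 3 to compound 4 (0.08 log units; within the scatter) in this assay, so the two groups cannot be told apart here. Within the data shown here, this is the first step read at this oxygen, and it shows that a six-membered aromatic ring and a six-membered non-aromatic ring of carbon read alike on this core. No measured evidence accounts for this.

Open, going by these compounds, is how a longer chain such as phenethyl on this oxygen, or an amine or carboxylic acid on the benzyl ring, would read. On these data alone, whether cyclohexyl to benzyl reads the same on a core carrying trifluoromethyl also stays open.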